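Three Triaryl Hydroxyphenyl Pyridines Against Topoisomerase 1

The compounds below may be only part of what the source reports. "The series", "measured", "known", "first", "only" and "open" are said of these compounds alone.

Compound 1 `Oc1ccc(-c2cc(-c3ccc(O)cc3)nc(-c3ccc(O)cc3)c2)cc1` gives 3.8%; compound 2 `Oc1ccc(-c2cc(-c3ccc(O)cc3)nc(-c3cccc(O)c3)c2)cc1` gives 0%; compound 3 `Oc1ccc(-c2cc(-c3cccc(O)c3)nc(-c3ccccc3O)c2)cc1` gives 1.5%.

All three were tested in an assay on isolated protein for inhibition of DNA topoisomerase 1 (Homo sapiens), with a stated time of 30 min, tested at 100 uM; on this read-out lower numbers stand for less inhibition and higher numbers for more inhibition at the one concentration tested (going by the name of the read-out). The cores of compound 2 and compound 3 differ as follows: 2-hydroxyphenyl in place of 4-hydroxyphenyl on an aromatic carbon, and this gave a number 1.5 percentage points higher from compound 2 to compound 3 (within the scatter). The change from compound 2 to compound 1 is 4-hydroxyphenyl in place of 3-hydroxyphenyl on an aromatic carbon, giving a number 3.8 percentage points higher from compound 2 to compound 1 (within the scatter). Compound 4 `Oc1ccc(-c2cc(-c3ccc(O)cc3)nc(-c3ccccc3O)c2)cc1` is not yet measured; it arises from compound 3 by 4-hydroxyphenyl in place of 3-hydroxyphenyl on an aromatic carbon. This is the same kind of change as from compound 2 to compound 1, but the place differs: there it was meta to two 4-hydroxyphenyl groups, here meta to a 2-hydroxyphenyl group and a 4-hydroxyphenyl group. Because the earlier step was a number 3.8 percentage points higher from compound 2 to compound 1 (within the scatter), only a small step of a number 2.5 percentage points higher from compound 3 to compound 4 (within the scatter) is expected. Compound 4 is therefore estimated at 4%, between 0% and 12%.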

Compound 4, a percentage reported as inhibition, at one concentration (the size of the read-out at that concentration, not a potency): 0%
The estimate for compound 4 lay 4 percentage points above the measured number; the measured number falls inside the stated range.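

In this assay the change from 3-hydroxyphenyl to 4-hydroxyphenyl gave a number 1.5 percentage points lower from compound 3 to compound 4 (within the scatter) and this does not set the two cores apart: the same change on two cores in this assay, a number 3.8 percentage points higher (within the scatter) from compound 2 to compound 1 and a number 1.5 percentage points lower (within the scatter) from compound 3 to compound 4, 5.3 percentage points apart, within the scatter of two such steps. The change to 2-hydroxyphenyl gave no change at the digits printed from compound 2 to compound 4 (within the scatter) and a number 3.8 percentage points lower from compound 1 to compound 4 (within the scatter) and the comparison of cores reads the same way: the same change on two cores in this assay, a number 1.5 percentage points higher (within the scatter) from compound 2 to compound 3 and a number 3.8 percentage points lower (within the scatter) from compound 1 to compound 4, 5.3 percentage points apart, within the scatter of two such steps. So neither change is shown to depend on the core, but neither is shown to carry over as a real effect, as every step here stays within the scatter.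

The compounds shown leave open whether an amine or a carboxylic acid in place of the hydroxyl groups would give a step beyond the scatter on this core.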